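Formyl to chloro on the pendant phenyl: compound 4

The compounds below may be only part of what the source reports. "The series", "measured", "known", "first", "only" and "open" are said of these compounds alone.

Measured so far in a functional assay on NCI-H226 cells (Homo sapiens) for inhibition, read by sulforhodamine B assay, with a stated time of 48 h, tested at 10 uM; on this read-out higher numbers stand for more inhibition at the one concentration tested (going by the name of the read-out) and lower numbers for less inhibition:
compound 1, `c1ccc(-c2cn3ccnc3c(-c3ccc4ncn(C5CCCCC5)c4c3)n2)cc1`, 33.9%
compound 2, `COc1ccc(-c2cn3ccnc3c(-c3ccc4ncn(C5CCCCC5)c4c3)n2)cc1`, 35.9%
compound 3, `O=Cc1ccc(-c2cn3ccnc3c(-c3ccc4ncn(C5CCCCC5)c4c3)n2)cc1`, 0.53%

Compound 3 stands lowest of the three numbers. Its nearest neighbour is compound 1, where the step of a number 33.4 percentage points lower from compound 1 to compound 3 (beyond the scatter) is large and beyond the scatter; the step of a number 35.4 percentage points lower from compound 2 to compound 3 (beyond the scatter) is of the same kind. The step of a number 2 percentage points higher from compound 1 to compound 2 (within the scatter) lies within the scatter, so compound 1 and compound 2 cannot be ordered against each other.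

Compound 4 is `Clc1ccc(-c2cn3ccnc3c(-c3ccc4ncn(C5CCCCC5)c4c3)n2)cc1`. It differs from compound 3 by chloro in place of formyl on an aromatic carbon. For the measured compounds named here, no measured step carries a chloro group, so the only guide is that both steps into compound 3, formyl in place of hydrogen and formyl in place of methoxy, were large drops in this assay . Removing the formyl is therefore expected to undo most of that drop, and compound 4 is expected to return toward the level shared by compound 1 and compound 2, with the estimated step of a number 31.5 percentage points higher from compound 3 to compound 4 (beyond the scatter). The estimate for compound 4 in this assay is 32%, with a range from 10% to 52%.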

Compound 4, a percentage reported as inhibition, at one concentration (the size of the read-out at that concentration, not a potency): 19.4%
Compound 4: middle estimate off by 12.6 percentage points, on the high side, within the range that was stated.
By their numbers in this assay, from the lowest: compound 3; then compound 4; then compounds 1 and 2 (each within the scatter of the next).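

In this assay, the change from 4-formylphenyl to 4-chlorophenyl gives a number 18.9 percentage points higher from compound 3 to compound 4 (beyond the scatter) and so recovers only part of the level seen without formyl. Chloro still falls short of both neighbours, with a number 14.5 percentage points lower from compound 1 to compound 4 (beyond the scatter) and a number 16.5 percentage points lower from compound 2 to compound 4 (beyond the scatter), so removing formyl does not by itself restore that level, and this position separates three groups rather than only formyl from the rest. No supporting data bear on why the groups fall in this order.

From the compounds shown here alone, whether an amine or a carboxylic acid at this position would fall with compound 3, with compound 4 or with compounds 1 and 2 remains open. Also open, going by these compounds, is whether fluoro or bromo would track chloro, and how the order seen at this one concentration would carry over to full potency measurements.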